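Adding One Fluorine: What Solubility Might Do

The compounds below may be only part of what the source reports. "The series", "measured", "known", "first", "only" and "open" are said of these compounds alone.

Four close relatives share a core, and three of them have been measured. Compound 1 is `COc1ccc(-n2cnc3cnc(-c4ccccc4C)cc32)cc1OC`. In a physicochemical assay for solubility (on this read-out higher numbers stand for higher solubility and lower numbers for lower solubility), compound 1 gives a limit of the assay, > 200000 nM. This is the case recorded as the limit of > 200000 nM in this assay, at which 1 of the 3 values shown sits. Compound 2 is `COc1ccc(-n2cnc3cnc(-c4cc(F)ccc4C)cc32)cc1OC`, which differs from compound 1 by fluoro in place of hydrogen on an aromatic carbon. In this assay compound 2 gives 157000 nM. That change produced an at least 1.2-fold lower number from compound 1 to compound 2 (0.10 log units; that floor lies within the scatter). Compound 3 is `COc1ccc(-n2cnc3cnc(-c4ccc(F)cc4C)cc32)cc1`; the difference between its core and the core of compound 1 is not broken down here. In this assay compound 3 gives 117000 nM, a number close to that of compound 2, too close to say which is the more soluble.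

Compound 4, `COc1ccc(-n2cnc3cnc(-c4ccc(F)cc4C)cc32)cc1F`, has not yet been measured. It differs from compound 3 by fluoro in place of hydrogen on an aromatic carbon. Among the measured compounds shown here, this is the same kind of change as the one from compound 1 to compound 2, but the surroundings differ: in compound 2 the fluoro sits meta to a large group and para to a methyl group, whereas in compound 4 it sits ortho to a methoxy group and meta to a large group.

Resting on the earlier change, which gave an at least 1.2-fold lower number from compound 1 to compound 2 (0.10 log units; that floor lies within the scatter), the step meant by this estimate is expected to be a 1.2-fold lower number from compound 3 to compound 4 (0.07 log units; within the scatter). Compound 4 is therefore estimated at 100000 nM in this assay, most likely between 50000 nM and 200000 nM.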

Compound 4, solubility: 49000 nM
Beside the measured number, compound 4's estimate is 2.0-fold (0.31 log units) above it, and the stated range ends above it.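

Placed ortho to a methoxy group and meta to a large group, fluoro in place of hydrogen on an aromatic carbon gives a step in this assay that can be read in full: a 2.4-fold lower number from compound 3 to compound 4 (0.38 log units; beyond the scatter). The same kind of change on the core of compound 1 gives an at least 1.2-fold lower number from compound 1 to compound 2 (0.10 log units; that floor lies within the scatter), so both steps are recorded as lower numbers, but this single pair of steps does not show that the change will have the same size, or even the same direction, on every core in this series, and the second step is the only one here that clearly exceeds the scatter. Compound 1 stands at a limit of the assay rather than at a number, so the earlier step gives only a floor and the true sizes of the two steps cannot be compared: the limit of > 200000 nM in this assay, at which 1 of the 4 values shown sits.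

The compounds shown leave open whether a different group in the same place, such as an amine, a carboxylic acid or a longer chain, would give a step in the same direction. They also leave open whether fluoro elsewhere on the same ring would give a step of similar size.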